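Removing the ring methyl from compound 3

The compounds below may be only part of what the source reports. "The series", "measured", "known", "first", "only" and "open" are said of these compounds alone.

Compound 3 `CCn1c(=O)/c(=C2\Sc3ccc(C)cc3N2C)s/c1=C\c1ccncc1Nc1ccccc1Cl` gives 650 nM in a functional assay on MCF7 cells (Homo sapiens) for inhibition; a lower number here means a stronger inhibitor, a higher number a weaker inhibitor. For comparison, compound 1 `CCn1c(=O)/c(=C2\Sc3cc(F)ccc3N2C)s/c1=C\c1ccncc1Nc1ccccc1F` gives 230 nM in this assay, and compound 2 `CCn1c(=O)/c(=C2\Sc3ccccc3N2C)s/c1=C\c1ccncc1Nc1cc(C)ccc1C` gives 1700 nM. Compound 3 therefore stands second highest of the three numbers, sitting between compound 1 on the lower side and compound 2 on the higher side, and the gap to each lies beyond the scatter. Going by the values given here, no two of these three compounds differ in only one place, so no single-change step among the measured compounds can be read off.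

Compound 4 `CCn1c(=O)/c(=C2\Sc3ccccc3N2C)s/c1=C\c1ccncc1Nc1ccccc1Cl` has not been measured. It differs from compound 3 by hydrogen in place of methyl on an aromatic carbon of the fused system. Among the compounds with values here, with no comparable step available, the expectation rests on the small size of the change alone: the step expected is a 1.2-fold higher number from compound 3 to compound 4 (0.09 log units; within the scatter), slight and if anything toward a higher number, not clearly beyond the scatter. Compound 4 is estimated at 800 nM in this assay, within a range from 300 nM to 2200 nM.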

Compound 4, half-maximal inhibitory concentration: 750 nM
Compound 4: the middle estimate sits 1.1-fold (0.03 log units) above what was measured; the range from low to high includes it.
By their numbers in this assay, from the lowest: compound 1; then compounds 3 and 4 (each within the scatter of the next); then compound 2.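

In this assay, going by these compounds alone, hydrogen in place of methyl on an aromatic carbon gives a 1.2-fold higher number from compound 3 to compound 4 (0.06 log units; within the scatter) and so leaves the number within the scatter; this is the first direct reading at this position, and in this pair the methyl is dispensable. Within the data shown here, compound 4 also gives the first readable step on the other side of the series, where 2-chlorophenyl in place of 2,5-dimethylphenyl on a nitrogen on an aromatic ring gives a 2.3-fold lower number from compound 2 to compound 4 (0.36 log units; beyond the scatter) as a modest change beyond the scatter. Nothing measured here bears on the reason for either step.

The compounds shown leave open whether this aromatic carbon would also accept a larger or more polar group, such as methoxy or an amine. They also leave open whether the tolerance for methyl holds with aryl groups on the nitrogen other than 2-chlorophenyl.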